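The compounds below may be only part of what the source reports. "The series", "measured", "known", "first", "only" and "open" are said of these compounds alone.

The account begins with compound 1 `Cn1cccc(NCc2cc3cc(Cl)ccc3[nH]c2=O)c1=O`. In an ADME assay on microsomes from liver (Homo sapiens) for metabolic stability, with a stated time of 30 min (on this read-out higher numbers stand for a more stable compound and lower numbers for a less stable compound), compound 1 gives 90%. Compound 3 `CCn1cccc(NCc2cc3cc(Cl)ccc3[nH]c2=O)c1=O` carries the change (methyl in place of hydrogen on a saturated chain carbon bound to an aromatic nitrogen), and in this assay compound 3 gives 72%, which is a number 18 percentage points lower from compound 1 to compound 3 (beyond the scatter).

Compound 2 `C[C@H](Nc1ccc(C#N)n(C)c1=O)c1cc2cc(Cl)c(OCc3ccccn3)cc2[nH]c1=O` rests on a different core, and the difference between the two cores is not broken down here. In this assay compound 2 gives 66%. Set against compound 3, the value of compound 2 lies within the usual scatter; set against compound 1, it lies beyond it.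

Compound 4 `C[C@H](Nc1ccc(C#N)n(C)c1=O)c1cc2cc(Cl)c(O[C@H](C)c3ccccn3)cc2[nH]c1=O` is not yet measured. It differs from compound 2 by methyl in place of hydrogen on a saturated chain carbon bound to an aromatic carbon and an oxygen on an aromatic ring. Within the data shown here, this is the same kind of change as the one from compound 1 to compound 3, but not the same: there the added methyl sits on a saturated chain carbon bound to an aromatic nitrogen, whereas here it sits on a saturated chain carbon bound to an aromatic carbon and an oxygen on an aromatic ring.

Among the measured compounds shown here, the only guide is the earlier step, a number 18 percentage points lower from compound 1 to compound 3 (beyond the scatter), and on that the step for compound 4 is expected to be a number 12 percentage points lower from compound 2 to compound 4 (beyond the scatter). Given that the place differs and the core differs, compound 4 is estimated to give 54% in this assay, with a likely range from 36% to 72%.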

Compound 4, percent of the compound remaining in the Homo sapiens assay: 70%
Beside the measured number, compound 4's estimate is 16 percentage points below it, within the range that was stated.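

In the Homo sapiens assay the new step reads a number 4 percentage points higher from compound 2 to compound 4 (within the scatter). In a physicochemical assay for solubility (a lower number here means a less soluble compound, a higher number a more soluble compound), compound 2 gives 2500 nM and compound 4 gives 1600 nM, and the step reads a 1.6-fold lower number from compound 2 to compound 4 (0.19 log units; within the scatter), so neither read-out separates the two compounds. Set beside the earlier step, the result from one core does not carry over to the other in the Homo sapiens assay: the same change on two cores in the Homo sapiens assay, a number 18 percentage points lower (beyond the scatter) from compound 1 to compound 3 and a number 4 percentage points higher (within the scatter) from compound 2 to compound 4, 22 percentage points apart, beyond the scatter of two such steps. This shows that the drop seen with the core of compound 1 cannot be assumed for the core of compound 2, but it does not show that the core alone sets the gap, as the methyl also stands in a different place in each pair, on a saturated chain carbon bound to an aromatic nitrogen in one and on a saturated chain carbon bound to an aromatic carbon and an oxygen on an aromatic ring in the other, and each step rests on a single pair of compounds.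

The compounds shown leave open whether the flat result for 1-(pyridin-2-yl)ethoxy would hold for a longer chain on the same carbon, such as 1-(pyridin-2-yl)propoxy. They also leave open what an amine or a carboxylic acid on the pyridin-2-yl group would do to either read-out.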